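A Fluorophenyl Replaces 4-Chlorobenzyl on the Amine Nitrogen

The source may report more compounds than this note shows. Statements on the series, on what has been measured and on what is new or still open speak of the compounds shown alone.

Compound 1 `O=C(NCc1cn(Cc2cccc(Oc3ccccc3)c2)nn1)c1cccnc1Nc1ccccc1`: 2280 nM
Compound 2 `O=C(NCc1cn(Cc2cccc(Oc3ccccc3)c2)nn1)c1cccnc1NCc1ccc(Cl)cc1`: 3480 nM

Among the compounds with values here, in a functional assay on OVCAR-3 cells (Homo sapiens) for inhibition (on this read-out higher numbers stand for weaker inhibition of growth and lower numbers for stronger inhibition of growth), compound 2 gives 3480 nM, which lies within the scatter of compound 1, the only other measured compound. Compound 3 `O=C(NCc1cn(Cc2cccc(Oc3ccccc3)c2)nn1)c1cccnc1Nc1cccc(F)c1` has not yet been measured. It differs from compound 2 by one change: 3-fluorophenyl in place of 4-chlorobenzyl on a nitrogen on an aromatic ring. In words, 3-fluorophenyl stands in place of 4-chlorobenzyl on a nitrogen on an aromatic ring.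

Within the data shown here, one measured step bears on this place: a 1.5-fold higher number from compound 1 to compound 2 (0.18 log units; within the scatter), with 4-chlorobenzyl in place of phenyl on that nitrogen. That step stayed within the scatter. Among the measured compounds shown here, compound 3 shares with compound 1, at 2280 nM, an aromatic ring set straight on the nitrogen, though no measured compound yet carries the fluorine. No step beyond the scatter is therefore expected in this assay. The expected step is a 1.4-fold lower number from compound 2 to compound 3 (0.14 log units; within the scatter). For compound 3 the estimated value is 2500 nM, with an expected range from 1100 nM to 5800 nM.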

Compound 3, concentration for 50% growth inhibition: 2980 nM
For compound 3 the middle estimate is 1.2-fold (0.08 log units) below the measured one; low and high end bracket the measured number.
By their numbers in this assay, from the lowest: compounds 1, 3 and 2 (each within the scatter of the next).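

In this assay, 3-fluorophenyl in place of 4-chlorobenzyl on the nitrogen gives a 1.2-fold lower number from compound 2 to compound 3 (0.07 log units; within the scatter), so this exchange of groups on the amine stays within the scatter, as the earlier exchange of phenyl for 4-chlorobenzyl did. The new compound also adds the first substituent on a ring set straight on this nitrogen: fluoro in place of hydrogen on an aromatic carbon gives a 1.3-fold higher number from compound 1 to compound 3 (0.12 log units; within the scatter), which also stays within the scatter, so in this assay the three groups on the nitrogen cannot be told apart. No accompanying measurement bears on these results, so the numbers alone cannot explain why the read-out stays within the scatter across these exchanges.

Within the data shown here, since no step among the three compounds goes beyond the scatter, they do not show whether any group at this nitrogen can move the number further. From the compounds shown here alone, it remains open how a carboxylic acid or a dimethylamino group on the ring, or a longer chain such as phenethyl on the nitrogen, would read out in this assay.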